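This account rests on a few compounds, and the source may have more. Where it says the series, first, only, none or still open, it means among the compounds named here.

Measured so far:

Compound 1, `CC(C)C[C@H](N)c1cc(C(F)(F)F)ccc1N1CCN(C(=O)COc2ccc3ccccc3c2)CC1`, gives 2000 nM in an assay on HEK293 cells for displacement of a labelled ligand from Melanocortin receptor 4 (Homo sapiens); a higher number here means a weaker inhibitor, a lower number a stronger inhibitor.
Compound 2, `CC(C)C[C@H](N)c1cc(C(F)(F)F)ccc1N1CCN(C(=O)CC(C)C(=O)c2ccc(Cl)cc2)CC1`, gives 1100 nM in this assay.
Compound 3, `Cc1ccc(OCC(=O)N2CCN(c3ccc(C(F)(F)F)cc3[C@@H](N)CC(C)C)CC2)cc1`, gives 4400 nM in this assay.

All three share one core and differ only in the group on the saturated chain carbon bound to the carbonyl carbon. Compound 3 has the highest number of the three: it is nearest to compound 1, as seen in a 2.2-fold higher number from compound 1 to compound 3 (0.34 log units; beyond the scatter), and furthest from compound 2, as seen in a 4.0-fold higher number from compound 2 to compound 3 (0.60 log units; beyond the scatter). The remaining pair is close, with a 1.8-fold lower number from compound 1 to compound 2 (0.26 log units; within the scatter).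

Compound 4, `CC(C)C[C@H](N)c1cc(C(F)(F)F)ccc1N1CCN(C(=O)CCNC2CCCCC2)CC1`, is the next member. Relative to compound 3 the change is (cyclohexylamino)methyl in place of 4-methylphenoxy on a saturated chain carbon bound to a carbonyl carbon. Among the compounds with values here, two measured steps touch the same place, a 2.2-fold higher number from compound 1 to compound 3 (0.34 log units; beyond the scatter) and a 4.0-fold higher number from compound 2 to compound 3 (0.60 log units; beyond the scatter), and both were modest; but neither of them brought in a hydrogen-bond donor or a non-aromatic ring at that position, so they give no direction for this change. The whole measured set spans only a narrow band, which suggests the position tolerates variation without large swings.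

Compound 4 is therefore expected to show a 1.5-fold lower number from compound 3 to compound 4 (0.17 log units; within the scatter), a step of uncertain direction and probably not large. The estimate for compound 4 in this assay is 3000 nM, with a range from 800 nM to 12000 nM.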

Compound 4, inhibition constant: 4800 nM
Compound 4: middle estimate off by 1.6-fold (0.20 log units), on the low side; low and high end bracket the measured number.
By their numbers in this assay, from the lowest: compounds 2 and 1 (each within the scatter of the next); then compounds 3 and 4 (each within the scatter of the next).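

Replacing 4-methylphenoxy with (cyclohexylamino)methyl on a saturated chain carbon bound to a carbonyl carbon exchanges an aromatic ring for a non-aromatic one and adds a hydrogen-bond donor, yet this assay shows no readable change (a 1.1-fold higher number from compound 3 to compound 4 (0.04 log units; within the scatter)). At this position, then, compound 4 stays level with compound 3 without an aryl ether, and it lies apart from the other two compounds by modest steps (a 4.4-fold higher number from compound 2 to compound 4 (0.64 log units; beyond the scatter); a 2.4-fold higher number from compound 1 to compound 4 (0.38 log units; beyond the scatter)). No measurement at hand accounts for this result or assigns any share of it to the ring or to the amine nitrogen.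

The ring and the linking atom change together in this step, so the compounds shown leave open how a (cyclohexyloxy)methyl group or a (phenylamino)methyl group, each changing only one of the two, would read in this assay. They also leave open whether a carboxylic acid or a longer chain carrying the cyclohexylamine at this position would stay in the same narrow band.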